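The compounds below may be only part of what the source reports. "The series", "measured", "known", "first", "only" and "open" are said of these compounds alone.

Working notes on the pyrazoline series.

Compound 1 `Clc1ccc(C2CC(c3ccccc3)=NN2c2ccccc2)cc1` is the reference point for the step examined here. For the measured compounds named here, in an assay for inhibition of cathepsin H (Capra hircus), using Lineweaver-Burk analysis (on this read-out lower numbers stand for stronger inhibition and higher numbers for weaker inhibition), compound 1 gives 1170 nM, the lowest of the two numbers measured so far in this assay. Going by the values given here, the only neighbour is compound 2 `Cc1ccc(C2CC(c3ccccc3)=NN2c2ccccc2)cc1`, which in this assay gives 4180 nM; the single measured step, a 3.6-fold higher number from compound 1 to compound 2 (0.55 log units; beyond the scatter), swaps the chloro of compound 1 for a methyl on the same aromatic carbon and moves the number beyond the scatter in the weaker direction.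

Compound 3 `COc1ccc(C2CC(c3ccccc3)=NN2c2ccccc2)cc1` has not yet been measured in this assay. It differs from compound 1 in one place: methoxy in place of chloro on an aromatic carbon. The step from compound 1 to compound 2 is the only one that bears on this change, since it also removes the same chloro from the same aromatic carbon and puts a different group there; that step was modest, beyond the scatter, toward a higher number. On that basis the change to methoxy is expected to behave alike, with compound 3 estimated to show a higher number in this assay than compound 1, by about a 2.6-fold higher number from compound 1 to compound 3 (0.41 log units; beyond the scatter). The estimate for compound 3 is 3000 nM, with the range 1200 nM to 8000 nM; the measured value will show whether the methoxy follows the methyl.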

Compound 3, inhibition constant: 2120 nM
Compound 3: middle estimate off by 1.4-fold (0.15 log units), on the high side; the range from low to high includes it.
By their numbers in this assay, from the lowest: compounds 1, 3 and 2 (each within the scatter of the next, the first and the last beyond it).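

In this assay the 4-methoxyphenyl of compound 3 cannot be told apart from the 4-chlorophenyl of compound 1, the step being a 1.8-fold higher number from compound 1 to compound 3 (0.26 log units; within the scatter) and so the loss of the chloro from this aromatic carbon does not by itself carry a cost that the assay can resolve. Compound 3 is just as unresolved from the methyl of compound 2, at a 2.0-fold lower number from compound 2 to compound 3 (0.29 log units; within the scatter) and so this position now holds three groups of which only chloro and methyl, in compound 1 and compound 2, stand apart beyond the scatter, while methoxy lies within the scatter of both. No measurement at hand accounts for these numbers.

The compounds shown carry only chloro, methyl and methoxy on this carbon, which leaves open how an amine, a carboxylic acid or a longer alkoxy chain would read here. Also open, from the compounds shown here alone, is whether the same swaps give the same small steps when made elsewhere on the shared core.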